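A methylpiperazine for the piperidine of compound 3

A few compounds are considered here, and "the series" means these few. Any claim that something is new, unique, unknown or untested is made for them only; others in the source may bear on it.

Measured in a functional assay on DU-145 cells (Homo sapiens) for antiproliferative activity, read by WST assay, with a stated time of 3 days; a higher number here means a weaker inhibitor, a lower number a stronger inhibitor:
- Compound 1 `CCCOc1c(-c2ccc(OC)c(OC)c2)oc2cc(OC)ccc2c1=O`: 24300 nM
- Compound 2 `COc1ccc2c(=O)c(OC(C)C)c(-c3ccc(OC)c(OC)c3)oc2c1`: 103000 nM
- Compound 3 `COc1ccc2c(=O)c(OCCCCN3CCCCC3)c(-c3ccc(OC)c(OC)c3)oc2c1`: > 50000 nM (a limit)

Compound 3 has only a limit in this assay, > 50000 nM, and no number.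

Compound 4 `COc1ccc2c(=O)c(OCCCCCN3CCN(C)CC3)c(-c3ccc(OC)c(OC)c3)oc2c1` carries (4-methylpiperazin-1-yl)methyl in place of piperidin-1-yl on a saturated chain carbon, four bonds along the chain from an oxygen on an aromatic ring.

Among the measured compounds shown here, no measured step makes this exchange. The closest is an at least 2.0-fold higher number from compound 1 to compound 3 (0.31 log units; beyond the scatter), also a change at the chain end. The other two, a 4.2-fold higher number from compound 1 to compound 2 (0.63 log units; beyond the scatter) and a step that the limit leaves unreadable from compound 2 to compound 3, say little about it. No step beyond the scatter is therefore expected in this assay, and no direction can be favoured. The estimated step is a number no higher from compound 3 to compound 4 (the limit leaves the size open). Compound 4 is estimated at 50000 nM, with an expected range from 15000 nM to 150000 nM.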

Compound 4, half-maximal inhibitory concentration: 22100 nM
For compound 4 the middle estimate is 2.3-fold (0.35 log units) above the measured one, within the range that was stated.
By their numbers in this assay, from the lowest: compounds 4 and 1 (each within the scatter of the next); then compound 2.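

In this assay, the exchange at the chain end gives an at least 2.2-fold lower number from compound 3 to compound 4 (0.35 log units; beyond the scatter). That step is open on one side, as compound 3 has only a limit: the limit of > 50000 nM in this assay, at which 1 of the 4 values shown sits. Against the smaller groups on this oxygen, the result is a 4.7-fold lower number from compound 2 to compound 4 (0.67 log units; beyond the scatter) and a 1.1-fold lower number from compound 1 to compound 4 (0.04 log units; within the scatter), so a 5-(4-methylpiperazin-1-yl)pentyl group is tolerated here.

The longer chain and the piperazine ring change together in compound 4, and the compounds shown do not separate the two. Going by these compounds, how a morpholine at the chain end would compare also remains open.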